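The source may hold more compounds than are shown below. What is called first, only, known or untested is meant among the compounds shown, and "the series" means these compounds.

Measured compounds in a functional assay on CHO cells for inhibition of metabotropic glutamate receptor 5 (Rattus norvegicus), read by FLIPR and calcium flux; on this read-out lower numbers stand for stronger inhibition and higher numbers for weaker inhibition:
Compound 1, `Cc1ccc2ccc(-c3cccc(Cl)c3)cc2n1`, gives 14000 nM.
Compound 2, `Cc1ccc2ccc(-c3cccc(C(F)(F)F)c3)cc2n1`, gives > 10000 nM, which is a limit of this assay rather than a number.
Compound 3, `Cc1ccc2ccc(-c3cc(Cl)cc(C#N)c3)cc2n1`, gives 1.4 nM.

Compound 3 stands at the lowest of the numbers shown; the nearest measured neighbour is compound 1, and the step of a 10000-fold lower number from compound 1 to compound 3 (4.00 log units; beyond the scatter) separates the two. Compound 4, `Cc1ccc2ccc(-c3cc(Br)cc(C#N)c3)cc2n1`, has not yet been measured. It differs from compound 3 in one place: bromo in place of chloro on an aromatic carbon.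

Neither measured step swaps one halogen for another. The step that the limit leaves unreadable from compound 1 to compound 2 replaces a halogen with a different group, and its size cannot be read because compound 2 sits at the limit of > 10000 nM in this assay, at which 1 of the 3 values shown sits. The step of a 10000-fold lower number from compound 1 to compound 3 (4.00 log units; beyond the scatter) adds the cyano group, which compound 3 and compound 4 both carry, so it speaks to the shared part rather than to the swap. In this assay the change from chloro to bromo is therefore expected to give no step beyond the scatter, no change at the digits printed from compound 3 to compound 4 (within the scatter). Compound 4 is estimated at 1.4 nM, between 0.5 nM and 4 nM.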

Compound 4, half-maximal inhibitory concentration: 13 nM
Compound 4: the middle estimate sits 9.3-fold (0.97 log units) below what was measured; the measured number lies above the stated range.
By their numbers in this assay, from the lowest: compound 3; then compound 4; then compound 1.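

For the compounds shown here, replacing chloro with bromo, at the position meta to a cyano group, gives a 9.3-fold higher number from compound 3 to compound 4 (0.97 log units; beyond the scatter) in this assay, so this position distinguishes between two halogens, which no earlier pair could show. The two groups have the same counts of heavy atoms, hydrogen-bond donors and acceptors, so those counts do not separate them, and among the two compounds with the cyano group, chloro gives the lower number. Nothing measured here explains why the swap has this size.

The compounds shown leave open how a fluoro or a methoxy group at this position would compare, and whether the chloro-to-bromo step would look the same without the cyano group. The earlier step from chloro to trifluoromethyl still cannot be read, so it adds no further comparison at this position.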